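Aryl group exchange on the shared core: compound 3

This account rests on a few compounds, and the source may have more. Where it says the series, first, only, none or still open, it means among the compounds named here.

Measured so far:
compound 1 `COc1ccc(-c2cn3ccnc3c(-c3ccc4ncn(C5CCCCC5)c4c3)n2)cc1`: 62.2%
compound 2 `Fc1ccccc1-c1cn2ccnc2c(-c2ccc3ncn(C4CCCCC4)c3c2)n1`: 4.16%

In a functional assay on NCI-H23 cells (Homo sapiens) for inhibition, read by sulforhodamine B assay, with a stated time of 48 h, tested at 10 uM (on this read-out higher numbers stand for more inhibition at the one concentration tested (going by the name of the read-out) and lower numbers for less inhibition), compound 1 gives 62.2% and compound 2 gives 4.16%. Compound 2 stands lowest of the two numbers; its nearest neighbour is compound 1. For the measured compounds named here, the only measured step, a number 58 percentage points lower from compound 1 to compound 2 (beyond the scatter), is large and beyond the scatter.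

Compound 3 `c1csc(-c2cn3ccnc3c(-c3ccc4ncn(C5CCCCC5)c4c3)n2)c1` differs from compound 2 by thiophen-2-yl in place of 2-fluorophenyl on an aromatic carbon. Going by the values given here, no measured step involves a thiophen-2-yl; the one step shows only that the group at this place can move the read-out strongly, so a sizeable step in either direction cannot be excluded. Compound 3 is expected to give 25% (range 3% to 55%). The expected step is a number 20.8 percentage points higher from compound 2 to compound 3 (beyond the scatter).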

Compound 3, a percentage reported as inhibition, at one concentration (the size of the read-out at that concentration, not a potency): 5.95%
For compound 3 the middle estimate is 19.1 percentage points above the measured one, and the stated range covers the measured number.
By their numbers in this assay, from the lowest: compounds 2 and 3 (each within the scatter of the next); then compound 1.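

Thiophen-2-yl and 2-fluorophenyl cannot be told apart at this aromatic carbon (a number 1.8 percentage points higher from compound 2 to compound 3 (within the scatter)), so the change from a six-membered aromatic ring of carbon only to a five-membered one with a sulfur does not separate them here. Replacing 4-methoxyphenyl with thiophen-2-yl gives a large step (a number 56.3 percentage points lower from compound 1 to compound 3 (beyond the scatter)), so among the three compounds only compound 1 keeps a sizeable read-out. No evidence on the cause is at hand.

Still open, going by these compounds, is whether this read-out depends on the methoxy group itself or on any group at that ring carbon, which phenyl, 4-fluorophenyl or 4-hydroxyphenyl would help separate. Also open, on these data alone, is how an amine or a carboxylic acid on the aryl ring would read here.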